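A few compounds are considered here, and "the series" means these few. Any claim that something is new, unique, unknown or untested is made for them only; others in the source may bear on it.

Of the compounds shown here, three have so far been measured in an assay on isolated protein for inhibition of cathepsin S (Homo sapiens), read by fluorescence, with a stated time of 20 min; on this read-out lower numbers stand for stronger inhibition and higher numbers for weaker inhibition. Compound 1 `N#CCNC(=O)[C@@H]1C[C@@H](S(=O)(=O)c2ccccc2Cl)C[C@H]1C(=O)N1CCOCC1` gives 0.5 nM, and compound 2 `N#CCNC(=O)[C@@H]1C[C@@H](S(=O)(=O)c2ccccc2C(F)(F)F)C[C@H]1C(=O)N1CCOCC1` gives 0.9 nM. Within the data shown here, the only step between measured compounds that differ in one place is a 1.8-fold higher number from compound 1 to compound 2 (0.26 log units; within the scatter), a trifluoromethyl in place of chloro on an aromatic carbon. Compound 3 `N#CC1(NC(=O)[C@@H]2C[C@@H](S(=O)(=O)c3ccccc3)C[C@H]2C(=O)N2CC3(COC3)C2)CC1` gives 3 nM, the highest of the three numbers; its gaps to compound 2 and to compound 1 both lie beyond the scatter, but compound 3 differs from each of them in more than one place, so no single change can be read from those gaps.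

Compound 4 `N#CC1(NC(=O)[C@@H]2C[C@@H](S(=O)(=O)c3ccccc3)C[C@H]2C(=O)N2CCNCC2)CC1` is not yet measured. It differs from compound 3 in a group of 6 heavy atoms (4 carbon, 2 nitrogen; one six-membered non-aromatic ring with 2 hetero atoms) in place of a group of 7 heavy atoms (5 carbon, 1 nitrogen, 1 oxygen; 2 four-membered non-aromatic rings with 1 hetero atom each), on a carbonyl carbon. Among the measured compounds shown here, no measured step touches this part of the shared core: the one step that exists sits on the aromatic ring, so it gives no direct guide to the size or direction of the change here. In the absence of such a guide, compound 4 is expected to land close to compound 3, with the step of a 1.3-fold higher number from compound 3 to compound 4 (0.12 log units; within the scatter) estimated to stay within the scatter. In this assay compound 4 is therefore estimated at 4 nM, in a range from 1 nM to 15 nM.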

Compound 4, half-maximal inhibitory concentration: 11 nM
For compound 4 the middle estimate is 2.8-fold (0.44 log units) below the measured one, within the range that was stated.
By their numbers in this assay, from the lowest: compounds 1 and 2 (each within the scatter of the next); then compound 3; then compound 4.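

Among these compounds, until now, the only step that could be read lay on the aromatic ring, so nothing showed how this assay responds to a change on the carbonyl carbon whose other neighbour is a saturated ring carbon. In this assay there is a 3.7-fold higher number from compound 3 to compound 4 (0.56 log units; beyond the scatter), a modest step beyond the scatter, which shows that this place is not indifferent to the exchange of the group with 2 four-membered rings for piperazin-1-yl. The entering group counts 1 hydrogen-bond donor where the leaving group counts 0, and both count 1 hydrogen-bond acceptor, but this single pair changes ring type and donor count together, and no measurement at hand bears on what lies behind the step.

On these data alone, whether a methyl or acetyl group on the second ring nitrogen of piperazin-1-yl, or an open-chain amine in its place, would move the number further remains open. As far as these compounds go, compounds 1 and 2 differ from compound 3 and compound 4 in more than one place, so it also remains open whether the same exchange would give a step of similar size on their core.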